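The compounds below may be only part of what the source reports. "The series", "measured", "known", "first", "only" and "open" are said of these compounds alone.

Measured so far:
- compound 1, `CCN(CC)S(=O)(=O)c1ccc(S(=O)(=O)N2CCC[C@@H](C(=O)NC3CCOCC3)C2)cc1`: 3770 nM
- compound 2, `CCN(CC)C(=O)c1ccc(S(=O)(=O)N2CCC[C@@H](C(=O)N3CCC(F)(F)CC3)C2)cc1`: 70 nM

Both numbers come from a functional assay on MIA PaCa-2 cells (Homo sapiens) for inhibition, read by MTT assay, with a stated time of 7 days; a higher number here means a weaker inhibitor, a lower number a stronger inhibitor. Compound 2 holds the lower of the two, and its gap to compound 1 is beyond the scatter; compound 1 and compound 2 differ in more than one place, so the two values alone do not tell which part of the structure carries the gap.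

Compound 3, `CC(C)NS(=O)(=O)c1ccc(S(=O)(=O)N2CCC[C@@H](C(=O)N3CCC(F)(F)CC3)C2)cc1`, is not yet measured. Compared with compound 2 the change is isopropylsulfamoyl in place of diethylcarbamoyl on an aromatic carbon. Among the measured compounds shown here, no measured pair isolates this change; the only other sulfonamide at that aromatic carbon is compound 1, which also carries a different amide and gives 3770 nM in this assay, so it serves at most as a loose pointer toward a weaker number.

For compound 3 the expected step in this assay is a 3.6-fold higher number from compound 2 to compound 3 (0.55 log units; beyond the scatter), a loss of some size rather than a gain, with wide uncertainty. The estimate for compound 3 is 250 nM, with a range from 60 nM to 1200 nM.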

Compound 3, half-maximal inhibitory concentration: 350 nM
For compound 3 the middle estimate is 1.4-fold (0.15 log units) below the measured one, and the stated range covers the measured number.
By their numbers in this assay, from the lowest: compound 2; then compound 3; then compound 1.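

In this assay, among the compounds shown here, this is the first change read in isolation at the aromatic carbon para to a large group, and it gives a 5.0-fold higher number from compound 2 to compound 3 (0.70 log units; beyond the scatter) with the rest of the structure held constant. The position therefore responds to the group it carries, and the response is a loss that leaves compound 3 with a measurable number. The heavy-atom count stays the same across the change and neither group has a ring or a net charge, while the entering isopropylsulfamoyl brings one hydrogen-bond donor and the leaving diethylcarbamoyl has none, but no data shown give a reason for the step.

The step bundles three differences: sulfonyl for carbonyl, the amide hydrogen, and isopropyl for two ethyl groups; isopropylcarbamoyl or diethylsulfamoyl on the same core would begin to separate them. Also open, going by these compounds, is how this aromatic carbon responds to groups of another kind, such as a carboxylic acid, a nitrile or a simple amine.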